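This account rests on a few compounds, and the source may have more. Where it says the series, first, only, none or still open, it means among the compounds named here.

Compound 1 `COc1cc(CNCc2ccc(C(=O)O)cc2)ccc1OCc1ccc(Cl)nc1`: "nd(insoluble)" (no result reported)
Compound 2 `COc1cc(CNCc2ccncc2)ccc1OCc1ccc(Cl)nc1`: 400 nM

In a functional assay on HeLa cells (Homo sapiens) for inhibition, with a stated time of 72 h (on this read-out higher numbers stand for an effect only at larger amounts of compound and lower numbers for an effect already at smaller amounts), compound 2 gives 400 nM. Within the data shown here, this is the only number available, so it cannot yet be ranked against anything. Compound 1 yielded no result, recorded as "nd(insoluble)" (no result reported).

Compound 3 `COCCNCc1ccc(OCc2ccc(Cl)nc2)c(OC)c1` has not yet been measured. It differs from compound 2 by one change: methoxymethyl in place of pyridin-4-yl on a saturated chain carbon bound to an amine nitrogen. The ring of compound 2 is thus replaced by an open chain. Among the measured compounds shown here, no step between measured compounds is available to size this change, so the expectation rests on the structural difference alone. A moderate move towards higher numbers, beyond the usual scatter, is expected, meaning a weaker effect. The expected step is a 3.8-fold higher number from compound 2 to compound 3 (0.57 log units; beyond the scatter). For compound 3 the estimated value is 1500 nM, with an expected range from 350 nM to 6500 nM.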

Compound 3, half-maximal effective concentration: 97000 nM
The estimate for compound 3 lay 65-fold (1.81 log units) below the measured number; the whole stated range lies below it.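

In this assay, methoxymethyl in place of pyridin-4-yl on a saturated chain carbon bound to an amine nitrogen gives a 240-fold higher number from compound 2 to compound 3 (2.38 log units; beyond the scatter), so the effect of this series depends strongly on what this place carries. The change removes a six-membered aromatic ring with 1 hetero atom and brings in an open chain, while the counts of hydrogen-bond donors and acceptors stay equal, so those counts alone do not separate compound 2 from compound 3. Nothing available explains the size of this step.

Among these compounds, it remains open whether the ring itself or its nitrogen matters more, since only one ring and one open chain can be compared here. A plain unsubstituted phenyl, a piperidine ring or a longer alkyl chain in the same place would help to separate these readings.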